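The source may report more compounds than this note shows. Statements on the series, on what has been measured and on what is new or still open speak of the compounds shown alone.

Compound 1 `COc1ccc(Oc2ccc3c(NCCCNCc4cc(F)ccc4OC)ccnc3c2)cc1` is one of three compounds that share a core and have been tested in an ADME assay on HepG2 cells (Homo sapiens) for cytotoxicity, read by luminescence, CellTiter-Glo and ATP content, with a stated time of 72 h; on this read-out higher numbers stand for an effect only at larger amounts of compound and lower numbers for an effect already at smaller amounts. In this assay compound 1 gives 7000 nM, the second highest of the three numbers. Compound 2 `COc1ccc(Oc2ccc3c(NCCCNCc4cccc(OC)c4O)ccnc3c2)cc1` is nearest: in this assay compound 2 gives 5500 nM, and the step from compound 1 is a 1.3-fold lower number from compound 1 to compound 2 (0.10 log units; within the scatter). Compound 3 `COc1cccc(CNCCCNc2ccnc3cc(Oc4ccc(F)cc4)ccc23)c1O` is furthest: in this assay compound 3 gives 11000 nM, and the values of compound 1 and compound 3 lie close together. The step from compound 2 to compound 3 is a 2.0-fold higher number from compound 2 to compound 3 (0.30 log units; within the scatter).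

Compound 4 `COc1ccc(F)cc1CNCCCNc1ccnc2cc(CC3CCCCC3)ccc12` differs from compound 1 at the other end of the core: cyclohexylmethyl in place of 4-methoxyphenoxy on an aromatic carbon. The change sits on an aromatic carbon of the fused system, meta to a fused ring and para to a fused ring. Neither measured step touches this position; both concern the group on the saturated chain carbon bound to an amine nitrogen, and both stayed small. Within the data shown here, no measured step therefore bears directly on the change, and no step beyond the scatter is expected in this assay. The step from compound 1 to compound 4 is expected to be no change at the digits printed from compound 1 to compound 4 (within the scatter). Compound 4 is accordingly estimated at 7000 nM, with a range from 2500 nM to 20000 nM.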

Compound 4, half-maximal effective concentration: 1830 nM
Estimate against measurement, compound 4: 3.8-fold (0.58 log units) above; measured number outside the range, below it.
By their numbers in this assay, from the lowest: compound 4; then compounds 2, 1 and 3 (each within the scatter of the next).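

In this assay the 4-methoxyphenoxy position turns out to respond: replacing that whole group with cyclohexylmethyl gives a 3.8-fold lower number from compound 1 to compound 4 (0.58 log units; beyond the scatter) and brings the effect to smaller amounts of compound. The exchange of fluoro for methoxy gave only a 2.0-fold higher number from compound 2 to compound 3 (0.30 log units; within the scatter) by comparison, so here a change of the entire group moved the number where the smaller change did not. No measurement shown here explains the step.

Among these compounds, the single exchange removes the aromatic ring and both hydrogen-bond acceptors together, leaving open which of these differences goes with the lower number. Also open, on these data alone, is how a morpholine, a carboxylic acid or a longer chain at this aromatic carbon would read, and whether the step would hold with the other groups carried by compound 2 and compound 3.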